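The compounds below may be only part of what the source reports. "The series", "measured", "known", "first", "only" and "open" are said of these compounds alone.

Of the compounds shown here, three built on one shared core have been measured in a functional assay on NSCLC cells (Homo sapiens) for cytotoxicity, with a stated time of 48 h; a higher number here means a weaker inhibitor of growth, a lower number a stronger inhibitor of growth. Compound 1 `COc1cc(/C=C2/C(=O)N(C)c3ccc(O)cc32)cc(OC)c1OC` gives 24600 nM, compound 2 `COc1ccc2c(c1)/C(=C\c1cc(OC)c(OC)c(OC)c1)C(=O)N2C` gives 46800 nM and compound 3 `COc1cc(/C=C2\C(=O)N(C)c3ccc(Cl)cc32)cc(OC)c1OC` gives 28200 nM. Compound 2 thus stands within the usual scatter of both other compounds, so these numbers do not separate it from them.

Compound 4 `COc1ccc(CN2C(=O)/C(=C/c3cc(OC)c(OC)c(OC)c3)c3cc(OC)ccc32)cc1` differs from compound 2 in one place: 4-methoxyphenyl in place of hydrogen on a saturated chain carbon bound to an amide-type nitrogen in a ring. In plain terms, 4-methoxyphenyl takes the place of hydrogen on a saturated chain carbon bound to an amide-type nitrogen in a ring, which turns methyl into 4-methoxybenzyl.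

For the measured compounds named here, only one measured step links two compounds that differ in one place: a 1.9-fold higher number from compound 1 to compound 2 (0.28 log units; within the scatter). That change, methyl in place of hydrogen on an oxygen on an aromatic ring, is small in effect and stays within the scatter, but it lies elsewhere on the molecule. Going by the values given here, no measured compound varies the group on the amide-type nitrogen, so the data offer no direct guide to this much larger addition. The best expectation is therefore no step beyond the scatter, with no firm direction and a wide margin. The estimate amounts to an expected 1.3-fold lower number from compound 2 to compound 4 (0.13 log units; within the scatter). In this assay the estimated value for compound 4 is 35000 nM, with an expected range from 12000 nM to 90000 nM.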

Compound 4, concentration for total growth inhibition: 11200 nM
The estimate for compound 4 lay 3.1-fold (0.49 log units) above the measured number; the measured number lies below the stated range.
By their numbers in this assay, from the lowest: compound 4; then compounds 1, 3 and 2 (each within the scatter of the next).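

In this assay, turning methyl into 4-methoxybenzyl on the amide-type nitrogen in a ring gives a 4.2-fold lower number from compound 2 to compound 4 (0.62 log units; beyond the scatter), the only step shown here that lies beyond the scatter. For the compounds shown here, all the earlier compounds carry methyl at this nitrogen, so they could not show whether this position accepts a much larger group; this pair shows that it can, and that growth inhibition becomes stronger in this one case. Nothing measured alongside these numbers explains why this change lowers the number.

With a single pair, the effect cannot be divided among the parts of the new group: the added aromatic ring, the methoxy on it, and the saturated chain carbon that links it to the nitrogen. Going by these compounds, a plain benzyl or a simple ethyl group on the same nitrogen would help to separate these parts, and it also remains open whether 4-methoxybenzyl would give a similar step on the hydroxy-bearing compound 1 or the chloro-bearing compound 3.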